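Swapping a Methoxyphenyl Arm for a Phenoxy Arm

A few compounds are considered here, and "the series" means these few. Any claim that something is new, unique, unknown or untested is made for them only; others in the source may bear on it.

Measured compounds:
compound 1, `COc1ccc(-c2ccc(NC3=CC(=O)c4ncncc4C3=O)cc2)cc1`, gives 2300 nM.
compound 2, `O=C1C(Nc2cccc(B(O)O)c2)=CC(=O)c2ncncc21`, gives 9000 nM.

Two compounds share a common core carrying an aryl amine. In a functional assay on PANC-1 cells (Homo sapiens) for cytotoxicity, read by MTT assay, with a stated time of 72 h (on this read-out lower numbers stand for stronger inhibition and higher numbers for weaker inhibition), compound 1 gives 2300 nM. Among the compounds with values here, compound 2, `O=C1C(Nc2cccc(B(O)O)c2)=CC(=O)c2ncncc21`, is the only other compound with a number, and in this assay compound 2 gives 9000 nM. Compound 1 therefore stands lowest of the two numbers, and the gap to compound 2 lies beyond the usual scatter of such measurements.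

Compound 3, `O=C1C(Nc2ccc(Oc3ccccc3)cc2)=CC(=O)c2ncncc21`, has not yet been measured. It differs from compound 1 in one place: phenoxy in place of 4-methoxyphenyl on an aromatic carbon. The group that leaves and the group that enters are of similar size and both carry a single oxygen, so no large shift is expected. Since nothing measured tells how this particular change plays out, the expectation rests on the similarity of the two groups alone. The step of a 1.5-fold higher number from compound 1 to compound 3 (0.18 log units; within the scatter) is expected to be small and probably within the scatter. Compound 3 is therefore estimated at 3500 nM, with a range from 1200 nM to 10000 nM.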

Compound 3, half-maximal inhibitory concentration: 1800 nM
The estimate for compound 3 lay 1.9-fold (0.29 log units) above the measured number, and the stated range covers the measured number.
By their numbers in this assay, from the lowest: compounds 3 and 1 (each within the scatter of the next); then compound 2.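

In this assay, within the data shown here, the single change that separates these two compounds, para to a large group, gives a 1.3-fold lower number from compound 1 to compound 3 (0.11 log units; within the scatter) and so leaves the two compounds indistinguishable on this read-out. Among these compounds, this is the first direct reading of a single change at this position, since the earlier pair of compounds differed in more than one place, and it shows that this particular exchange, between two groups that each hold one six-membered aromatic ring and one oxygen, does not move the number beyond the scatter. Nothing available beyond the cell numbers themselves helps to explain this result.

As far as these compounds go, a single exchange between two such similar groups does not show how much change this position can accept, so it remains open whether a carboxylic acid, an amine or a short alkyl chain in the same place would keep the number or shift it. Also open, from the compounds shown here alone, is whether a longer chain, such as benzyloxy, would behave like phenoxy on this same aromatic carbon.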